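This account rests on a few compounds, and the source may have more. Where it says the series, first, only, none or still open, it means among the compounds named here.

Measured so far in a functional assay on HCT-116 cells (Homo sapiens) for cytotoxicity, read by MTT assay, with a stated time of 72 h; a lower number here means a stronger inhibitor, a higher number a weaker inhibitor:
- compound 1 `Cc1cc(-c2ccccc2)n(/C(N)=N/S(=O)(=O)c2cc(C)c(Cl)cc2SCc2ccccc2C(F)(F)F)n1`: 25000 nM
- compound 2 `Cc1cc(-c2ccccc2)n(/C(N)=N/S(=O)(=O)c2cc(C)c(Cl)cc2SCc2cccc(Cl)c2)n1`: 18000 nM

Compound 2 stands at one end of the two numbers shown, with compound 1 the only neighbour; the step of a 1.4-fold lower number from compound 1 to compound 2 (0.14 log units; within the scatter) does not separate the two, so on these numbers the pair cannot be told apart in this assay.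

Compound 3 `Cc1cccc(CSc2cc(Cl)c(C)cc2S(=O)(=O)/N=C(\N)n2nc(C)cc2-c2ccccc2)c1` is the next analogue. Relative to compound 2 the difference is methyl in place of chloro on an aromatic carbon.

Within the data shown here, only one measured step bears on this position: a 1.4-fold lower number from compound 1 to compound 2 (0.14 log units; within the scatter), which exchanged the whole 3-chlorophenyl for a 2-(trifluoromethyl)phenyl on the same saturated chain carbon bound to sulfur and stayed within the scatter. Among the measured compounds shown here, no measured step exchanges a chloro for a methyl at this aromatic carbon, so the evidence is indirect. Given that the larger exchange at the same ring left the number unchanged beyond the scatter, the smaller one is expected to do the same, and the step of no change at the digits printed from compound 2 to compound 3 (within the scatter) is estimated to lie within the scatter. For compound 3 in this assay the estimate is 18000 nM, with a range from 9000 nM to 36000 nM.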

Compound 3, half-maximal inhibitory concentration: 34000 nM
Compound 3: the middle estimate sits 1.9-fold (0.28 log units) below what was measured; the range from low to high includes it.
By their numbers in this assay, from the lowest: compounds 2, 1 and 3 (each within the scatter of the next).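

In this assay, the exchange of chloro for methyl on this aromatic carbon, 3-chlorobenzyl to 3-methylbenzyl, gives a 1.9-fold higher number from compound 2 to compound 3 (0.28 log units; within the scatter) and so does not separate the two groups at this position. Among these compounds, this direct exchange adds to the indirect reading available before, and 3-methylphenyl in place of 2-(trifluoromethyl)phenyl on the saturated chain carbon bound to a sulfur gives a 1.4-fold higher number from compound 1 to compound 3 (0.13 log units; within the scatter) with the same outcome, so no step among the three compounds lies beyond the scatter. Nothing shown offers an explanation for these small steps.

The compounds shown carry only chloro, methyl or trifluoromethyl on this phenyl group, so it remains open whether an amine or a carboxylic acid there would give a step beyond the scatter. Also open, going by these compounds, is whether a longer chain in place of the saturated chain carbon bound to a sulfur, or a change elsewhere on the shared core, would move the number in this assay beyond the scatter.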